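The source may hold more compounds than are shown below. What is called first, only, known or untested is meant among the compounds shown, and "the series" means these compounds.

The measured compounds:
compound 1 `CC(C)[C@H](C(=O)Nc1cccnn1)c1ccc(Cl)cc1` gives 101% in a functional assay on CHO cells for agonist activity at Free fatty acid receptor 2 (Homo sapiens), read by cAMP accumulation; a higher number here means a larger maximal response, a lower number a smaller maximal response;
compound 2 `CC(C)[C@H](C(=O)Nc1ccon1)c1ccc(Cl)cc1` gives 90% in this assay;
compound 3 `CC(C)[C@H](C(=O)Nc1ncc(C(F)(F)F)s1)c1ccc(Cl)cc1` gives 95% in this assay.

All three share one core and differ only in the ring attached to the amide-type nitrogen. For the measured compounds named here, the single step between two compounds that differ in one place is a number 11 percentage points lower from compound 1 to compound 2 (beyond the scatter). Compound 3 stands second of the three numbers, but its gaps to compound 2 and to compound 1 both lie within the scatter, so no order among the three can be read from these values.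

Compound 4 `CC(C)[C@H](C(=O)Nc1ncc(C#N)s1)c1ccc(Cl)cc1` keeps the five-membered aromatic ring of compound 3 and alters only the group on it: cyano in place of trifluoromethyl on an aromatic carbon. Going by the values given here, no measured step swaps a group on this ring; the one measured step exchanged the whole ring and was modest. Since all three measured compounds lie close together, no step beyond the scatter in this assay is expected for compound 4, and the estimated step is a number 2 percentage points lower from compound 3 to compound 4 (within the scatter). Compound 4 is therefore estimated at 93%, with a range from 80% to 105%.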

Compound 4, largest response reached (reported as efficacy), in percent of the reference or control that the assay uses: 105%
For compound 4 the middle estimate is 12 percentage points below the measured one; the measured number falls inside the stated range.
By their numbers in this assay, from the lowest: compounds 2, 3, 1 and 4 (each within the scatter of the next, the first and the last beyond it).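

For the compounds shown here, on the five-membered aromatic ring with one nitrogen and one sulfur, this is the first measured swap of a group on an aromatic carbon next to the ring sulfur: in this assay, cyano in place of trifluoromethyl gives a number 10 percentage points higher from compound 3 to compound 4 (within the scatter), so this position accepts a group of 2 heavy atoms in place of one of 4 without a change that can be told from the scatter. Comparing whole rings on the amide-type nitrogen, a number 4 percentage points higher from compound 1 to compound 4 (within the scatter) stays inside the scatter, while a number 15 percentage points higher from compound 2 to compound 4 (beyond the scatter) goes beyond it, so only the 1,2-oxazol-3-yl ring stands apart from the 5-cyano-1,3-thiazol-2-yl ring. No measurement at hand explains these numbers.

On these data alone, whether an amine, a carboxylic acid or a longer chain on this carbon would keep the response remains open. Also open, as far as these compounds go, is the concentration needed to reach it, since only the largest response is given here.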